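This account rests on a few compounds, and the source may have more. Where it says the series, first, only, none or still open, it means among the compounds named here.

Compound 1, `O=C(NCc1cn(Cc2ccc(F)cc2)nn1)c1cn(-c2ccccc2)nc1-c1ccc(F)cc1`, carries a 4-fluorophenyl on the saturated chain carbon bound to an aromatic nitrogen and a second 4-fluorophenyl on the core. In a functional assay on MIA PaCa-2 cells (Homo sapiens) for antiproliferative activity, read by sulforhodamine B assay, with a stated time of 48 h (on this read-out lower numbers stand for stronger inhibition of growth and higher numbers for weaker inhibition of growth), compound 1 gives 14300 nM, the highest of the two numbers recorded; the nearest is compound 3, `COc1cc(Cn2cc(CNC(=O)c3cn(-c4ccccc4)nc3-c3ccc(F)cc3)nn2)cc(OC)c1`, which in this assay gives 190 nM. Compound 2, `COc1ccc(Cn2cc(CNC(=O)c3cn(-c4ccccc4)nc3-c3ccc(F)cc3)nn2)cc1OC`, reaches only a limit of the assay, > 100000 nM, which is the limit of > 100000 nM in this assay, at which 1 of the 3 values shown sits. Every measured step changes the aryl on the saturated chain carbon bound to an aromatic nitrogen: an at least 6.9-fold higher number from compound 1 to compound 2 (0.84 log units; beyond the scatter), a 75-fold lower number from compound 1 to compound 3 (1.88 log units; beyond the scatter) and an at least 520-fold lower number from compound 2 to compound 3 (2.72 log units; beyond the scatter). Compound 4, `COc1ccc(-c2nn(-c3ccccc3)cc2C(=O)NCc2cn(Cc3ccc(F)cc3)nn2)cc1`, differs from compound 1 at another ring: methoxy in place of fluoro on an aromatic carbon. Within the data shown here, no measured step touches this ring, so the large swings seen at the other aryl give no direct guide, and with nothing to build on the change is taken as neutral. For compound 4 the expected step is a 1.0-fold lower number from compound 1 to compound 4 (0.01 log units; within the scatter), none beyond the scatter. Compound 4 is thus estimated at 14000 nM, within 4000 nM to 50000 nM.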

Compound 4, concentration for 50% growth inhibition: 24100 nM
For compound 4 the middle estimate is 1.7-fold (0.24 log units) below the measured one, within the range that was stated.
By their numbers in this assay, from the lowest: compound 3; then compounds 1 and 4 (each within the scatter of the next). At a limit, above all of these: compound 2.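

In this assay, replacing fluoro with methoxy on the aromatic carbon para to a large group gives a 1.7-fold higher number from compound 1 to compound 4 (0.23 log units; within the scatter), so at this position compounds with 4-fluorophenyl and 4-methoxyphenyl cannot be told apart. This single change therefore stays within the scatter, whereas a change at the other aryl, on the saturated chain carbon bound to an aromatic nitrogen, gives a 75-fold lower number from compound 1 to compound 3 (1.88 log units; beyond the scatter). Nothing shown here bears on why the exchange leaves the reading within the scatter.

From the compounds shown here alone, whether this position would accept a very different group, such as an amine, a carboxylic acid or a longer alkoxy chain, remains open. Going by these compounds, it is also open whether methoxy here would read the same alongside the 3,5-dimethoxyphenyl of compound 3 rather than the 4-fluorophenyl of compound 1.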